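Swapping butoxy for fluoro on the shared core

The source may report more compounds than this note shows. Statements on the series, on what has been measured and on what is new or still open speak of the compounds shown alone.

- compound 1 `CC(C)COc1ccc2oc(/C=C/[S+](C)[O-])cc(=O)c2c1`: 5000 nM
- compound 2 `CCCC(=O)Oc1ccc2oc(/C=C/[S+](C)[O-])cc(=O)c2c1`: 8700 nM
- compound 3 `CCCCOc1ccc2oc(/C=C/[S+](C)[O-])cc(=O)c2c1`: 4800 nM

In a functional assay on DLD-1 cells (Homo sapiens) for cytotoxicity, with a stated time of 48 h (a lower number here means a stronger inhibitor, a higher number a weaker inhibitor), compound 3 gives 4800 nM and does not stand apart from the other two compounds: the data show a 1.0-fold lower number from compound 1 to compound 3 (0.02 log units; within the scatter) and a 1.8-fold lower number from compound 2 to compound 3 (0.26 log units; within the scatter). Compound 4 `C[S+]([O-])/C=C/c1cc(=O)c2cc(F)ccc2o1` carries fluoro in place of butoxy on an aromatic carbon. Among the compounds with values here, these two steps and a 1.7-fold higher number from compound 1 to compound 2 (0.24 log units; within the scatter) are the only guides, and they are weak ones. Each changes only the group on the oxygen, so none tests removing that oxygen or adding fluoro. All stayed within the scatter, so no clear step beyond it is expected, though with real uncertainty. The expected change is a 1.5-fold higher number from compound 3 to compound 4 (0.16 log units; within the scatter). For compound 4 the estimate is 7000 nM, with an expected range of 2500 nM to 20000 nM.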

Compound 4, half-maximal inhibitory concentration: 7000 nM
Beside the measured number, compound 4's estimate shows no gap at the digits printed, and the stated range covers the measured number.
By their numbers in this assay, from the lowest: compounds 3, 1, 4 and 2 (each within the scatter of the next).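

Replacing the whole oxygen-linked group with fluoro on this aromatic carbon gives no step beyond the scatter in this assay, with a 1.5-fold higher number from compound 3 to compound 4 (0.16 log units; within the scatter) and a 1.4-fold higher number from compound 1 to compound 4 (0.15 log units; within the scatter) and also a 1.2-fold lower number from compound 2 to compound 4 (0.09 log units; within the scatter) in this set. The earlier steps shown here changed only the group on the oxygen, whereas these show that compound 4 stays within the scatter of the others without that oxygen or its chain. As far as these compounds go, whether an amine or a carboxylic acid on this carbon would produce a clear step remains open. No measurement shown explains why these compounds read so alike.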